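Phenoxypropyl chain in place of hexyl on the thiazole series

The compounds below may be only part of what the source reports. "The series", "measured", "known", "first", "only" and "open" are said of these compounds alone.

Compound 2 `CCCCCCN(Cc1ccc(C(=O)NO)cc1)c1ncc(-c2ccc(C)cc2)s1` gives 5270 nM in a functional assay on PC-3 cells (Homo sapiens) for antiproliferative activity, read by MTT assay, with a stated time of 48 h; a higher number here means a weaker inhibitor of growth, a lower number a stronger inhibitor of growth. Among the three measured compounds it holds the second highest number: the nearest is compound 3 `Cc1ccc(OCCCN(Cc2ccc(C(=O)NO)cc2)c2ncc(-c3ccc(C)cc3)s2)cc1`, which gives 9330 nM; the furthest is compound 1 `Cc1ccc(OCCCCN(Cc2ccc(C(=O)NO)cc2)c2ncc(-c3ccc(C)cc3)s2)cc1`, which gives 1220 nM.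

Compound 4 `Cc1ccc(-c2cnc(N(CCCOc3ccccc3)Cc3ccc(C(=O)NO)cc3)s2)cc1` is not yet measured. Against compound 2 the change is phenoxy in place of propyl on a saturated chain carbon, three bonds along the chain from a nitrogen on an aromatic ring.

Going by the values given here, two measured steps bear on the question. a 1.8-fold higher number from compound 2 to compound 3 (0.25 log units; within the scatter) places a 4-methylphenoxy at exactly the position where the phenoxy of compound 4 enters, and that step stayed within the scatter. a 4.3-fold higher number from compound 1 to compound 2 (0.64 log units; beyond the scatter) and a 7.6-fold higher number from compound 1 to compound 3 (0.88 log units; beyond the scatter) show that the 4-methylphenoxy chain of compound 1, one bond longer, sits well apart from both the hexyl chain and the shorter 4-methylphenoxy chain. Among the compounds with values here, compound 4 differs from compound 3 only by the absence of the methyl on the aromatic ring of the phenoxy; no measured step covers that difference, so nothing can be said of it beyond the two values already given. Within the data shown here, the step from compound 2 to compound 4 is therefore expected to resemble the one to compound 3, a small rise in number that may fall within the scatter, a 1.4-fold higher number from compound 2 to compound 4 (0.15 log units; within the scatter).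

Compound 4 is estimated at 7500 nM in this assay, with a range from 2500 nM to 22000 nM.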

Compound 4, concentration for 50% growth inhibition: 17500 nM
The estimate for compound 4 lay 2.3-fold (0.37 log units) below the measured number; the measured number falls inside the stated range.
By their numbers in this assay, from the lowest: compound 1; then compounds 2, 3 and 4 (each within the scatter of the next, the first and the last beyond it).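

In this assay, the unsubstituted 3-phenoxypropyl chain gives a step beyond the scatter against the hexyl chain, a 3.3-fold higher number from compound 2 to compound 4 (0.52 log units; beyond the scatter), whereas the chain with 4-methylphenoxy at the same place had stayed within it. Going by these compounds alone, the change of hydrogen in place of methyl on an aromatic carbon is the first direct reading of the ring methyl, and at a 1.9-fold higher number from compound 3 to compound 4 (0.27 log units; within the scatter) it lies within the scatter, so the two phenoxypropyl compounds cannot be told apart and the methyl has no demonstrated effect at this chain length. The gap to the chain one bond longer carrying 4-methylphenoxy now reaches a 14-fold higher number from compound 1 to compound 4 (1.16 log units; beyond the scatter), the largest step in the set, though that step changes both chain length and the ring methyl at once.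

No measurement at hand accounts for any of these steps. Still open, going by these compounds, are whether a chain longer than that of compound 1 extends the trend, and whether a chlorine or a methoxy in place of the methyl on the aromatic carbon would matter at either chain length.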